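A few compounds are considered here, and "the series" means these few. Any claim that something is new, unique, unknown or untested is made for them only; others in the source may bear on it.

Measured so far in a functional assay on PBMC cells (Homo sapiens) for inhibition, read by HTRF, with stated times of 15 min and 24 h; a higher number here means a weaker inhibitor, a lower number a stronger inhibitor:
- Compound 1 `O=C(Nc1ccc2c(c1)B(O)OC2)c1ccccc1C(F)(F)F` gives 4400 nM in this measurement
- Compound 2 `O=C(Nc1ccc2c(c1)B(O)OC2)c1ccccc1Cl` gives > 100000 nM as a limit of the assay, not a number
- Compound 3 `O=C(Nc1ccc2c(c1)B(O)OC2)c1cc(F)ccc1C(F)(F)F` gives 8200 nM in this measurement

Compound 3 and compound 1 lie within the scatter of each other, so neither can be ranked above the other. Compound 2 is known only as a limit.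

Compound 4 `O=C(Nc1ccc2c(c1)B(O)OC2)c1cc(C(F)(F)F)ccc1C(F)(F)F` differs from compound 3 at one place, counted as trifluoromethyl in place of fluoro on an aromatic carbon and in words trifluoromethyl in place of fluoro on an aromatic carbon, para to a trifluoromethyl group. For the measured compounds named here, two measured steps bear on this change. The step of a 1.9-fold higher number from compound 1 to compound 3 (0.27 log units; within the scatter) put fluoro in place of hydrogen on that same carbon and stayed within the scatter. The step of an at least 22-fold higher number from compound 1 to compound 2 (1.35 log units; beyond the scatter) is large, but it put chloro in place of trifluoromethyl on another aromatic carbon and so says little directly about this one.

The closest guide is therefore compound 3 at 8200 nM in the same measurement. No step beyond the scatter is expected in this assay for this change, although the range stays wide since trifluoromethyl has not been measured on this carbon. The estimated change is a 1.1-fold higher number from compound 3 to compound 4 (0.04 log units; within the scatter) and no more than that. For compound 4 the estimate is 9000 nM with an expected range of 3000 nM to 30000 nM in this measurement.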

Compound 4, half-maximal inhibitory concentration: 3000 nM
The estimate for compound 4 lay 3.0-fold (0.48 log units) above the measured number; measured number inside the range.
By their numbers in this assay, from the lowest: compounds 4, 1 and 3 (each within the scatter of the next, the first and the last beyond it). At a limit, above all of these: compound 2.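

In this assay, the carbon para to a trifluoromethyl group accepts a second trifluoromethyl group with no loss that can be read: a 1.5-fold lower number from compound 1 to compound 4 (0.17 log units; within the scatter), so the two compounds cannot be ranked. Replacing fluoro with trifluoromethyl on this carbon does register, however: a 2.7-fold lower number from compound 3 to compound 4 (0.44 log units; beyond the scatter), whereas the earlier step on the same carbon stayed inside the scatter: a 1.9-fold higher number from compound 1 to compound 3 (0.27 log units; within the scatter). The carbon therefore tells trifluoromethyl from fluoro, though only modestly, while hydrogen cannot be separated from either group.

As far as these compounds go, what an amine, a methoxy group or a carboxylic acid would do on this same carbon stays open, as does whether any group placed there could bring the number far below the values seen so far. Nothing measured here explains the difference between fluoro and trifluoromethyl on this carbon.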